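Notes on the step to compound 3

The source may report more compounds than this note shows. Statements on the series, on what has been measured and on what is new or still open speak of the compounds shown alone.

Measured in a physicochemical assay for solubility, at pH 7; on this read-out higher numbers stand for higher solubility and lower numbers for lower solubility (both values are limits):
- compound 1 `CN1CCC(C(=O)N2Cc3c(NC(=O)c4ccc(Cl)cc4)n[nH]c3C2(C)C)CC1` gives > 225000 nM
- compound 2 `CN1CCC(C(=O)N2Cc3c(NC(=O)c4ccc(F)c(F)c4)n[nH]c3C2(C)C)CC1` gives > 225000 nM

Compound 2 has only a limit (> 225000 nM) and no number. The other compound shares that limit (the limit of > 225000 nM in this assay, at which 2 of the 2 values shown sit). The next structure is compound 3 `CN1CCC(C(=O)N2Cc3c(NC(=O)c4ccncc4)n[nH]c3C2(C)C)CC1` and the change is pyridin-4-yl in place of 3,4-difluorophenyl on a carbonyl carbon in words, pyridin-4-yl in place of 3,4-difluorophenyl on a carbonyl carbon. Among the compounds with values here, the one measured step at that carbonyl carbon (a step that the two limits leave unreadable from compound 1 to compound 2) has no readable size, so no measured size carries over. No step beyond the scatter is expected in this assay and a further limit is the likely report. This expectation rests on compound 2 and its limit (> 225000 nM). The expected step is a number no higher from compound 2 to compound 3 (the limit leaves the size open) by this estimate. For compound 3 the estimated value is 225000 nM (expected range 120000 nM to 400000 nM).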

Compound 3, solubility: > 225000 nM
Compound 3: a limit, no number (the forecaster's own chance of this, stated with the estimate: 85%); the middle value lies on the limit itself.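

No new step can be read in this assay: compound 1, compound 2 and compound 3 are reported only as limits, so the steps among them stay unreadable. The compounds shown leave open whether 4-chlorophenyl, 3,4-difluorophenyl and pyridin-4-yl on the carbonyl carbon differ at all: the limit of > 225000 nM in this assay, at which 3 of the 3 values shown sit.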